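A few compounds are considered here, and "the series" means these few. Any claim that something is new, unique, unknown or untested is made for them only; others in the source may bear on it.

Measured so far:
Compound 1 `CCCN1CCN(c2ccc(S(=O)(=O)Oc3ccc(OC)c(OC)c3)cc2)C1=O` gives 28000 nM in a functional assay on M21 cells (Homo sapiens) for antiproliferative activity, read by sulforhodamine B assay, with a stated time of 48 h; on this read-out lower numbers stand for stronger inhibition and higher numbers for weaker inhibition.
Compound 2 `CCCCN1CCN(c2ccc(S(=O)(=O)Oc3ccccc3)cc2)C1=O` gives > 100000 nM in this assay, which is a limit of the assay rather than a number.
Compound 3 `CCCCN1CCN(c2ccc(S(=O)(=O)Oc3cccc(F)c3)cc2)C1=O` gives > 100000 nM in this assay, also a limit of the assay and not a number.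

Compound 3 therefore stands at a limit, as does one other value of the three. The step that the two limits leave unreadable from compound 2 to compound 3 cannot be read because of the limit of > 100000 nM in this assay, at which 2 of the 3 values shown sit. Compound 4 `CCCCN1CCN(c2ccc(S(=O)(=O)Oc3ccc(OC)c(OC)c3)cc2)C1=O` is not yet measured; it differs from compound 3 by 3,4-dimethoxyphenyl in place of 3-fluorophenyl on an oxygen. For the measured compounds named here, no measured step covers this change, and the limits at compound 2 and compound 3 give no readable direction. Compound 1 carries the same 3,4-dimethoxyphenyl and gives a number in this assay. Compound 4 is expected to come near that, estimated at 30000 nM, with a range from 10000 nM to 100000 nM. The expected step of an at least 3.3-fold lower number from compound 3 to compound 4 (0.52 log units; beyond the scatter) is thus estimated only from the limit side, loosely.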

Compound 4, half-maximal inhibitory concentration: > 100000 nM
Compound 4 gave a limit, no number; the forecaster's own chance of this, stated with the estimate: 30%; at least 3.3-fold (0.52 log units) between middle value and limit.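

With 3,4-dimethoxyphenyl held fixed in this assay, methyl in place of hydrogen on a saturated chain carbon, three bonds along the chain from an amide-type nitrogen in a ring, gives an at least 3.5-fold higher number from compound 1 to compound 4 (0.55 log units; beyond the scatter). On the longer chain, 3,4-dimethoxyphenyl therefore does not bring a readable number. The steps among compound 2, compound 3 and compound 4 cannot be read: the limit of > 100000 nM in this assay, at which 3 of the 4 values shown sit.

Going by these compounds, whether phenyl or 3-fluorophenyl gives a number on the chain of compound 1 stays open. So does the reading with an ethyl chain, or a chain carrying an amine.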